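One methoxy fewer on compound 2

This account rests on a few compounds, and the source may have more. Where it says the series, first, only, none or still open, it means among the compounds named here.

Measured in a functional assay on L1210 cells (Mus musculus) for antiproliferative activity, read by MTT assay, with a stated time of 72 h; on this read-out higher numbers stand for weaker inhibition and lower numbers for stronger inhibition:
- compound 1 `COc1ccccc1C1OC(c2cc(OC)c(OC)c(OC)c2)=NN1C(C)=O`: 48000 nM
- compound 2 `COc1cc(C2=NN(C(C)=O)C(c3cc(OC)c(OC)c(OC)c3)O2)cc(OC)c1OC`: > 100000 nM

Compound 2 gives no number in this assay: its entry, > 100000 nM, is a limit. It stands at the limit of > 100000 nM in this assay, at which 1 of the 2 values shown sits. Compound 1 does give a number, 48000 nM.

Compound 3 `COc1cc(OC)cc(C2OC(c3cc(OC)c(OC)c(OC)c3)=NN2C(C)=O)c1` is compound 2 with one change, hydrogen in place of methoxy on an aromatic carbon. That carbon is ortho to two methoxy groups and para to a large group. For the measured compounds named here, no measured step covers this change, so the size of the move in this assay can only be expected. A small step toward stronger inhibition is expected, and compound 3 may well also return only a limit. Going by the values given here, the one number available, compound 1 at 48000 nM, is the anchor for that expectation. The estimated move is an at least 1.4-fold lower number from compound 2 to compound 3 (0.15 log units; that floor lies within the scatter). For compound 3 the expected value is 70000 nM, with an estimated range from 25000 nM to 150000 nM.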

Compound 3, half-maximal inhibitory concentration: 5900 nM
The estimate for compound 3 lay 12-fold (1.07 log units) above the measured number; measured number below the stated range.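

In this assay, hydrogen in place of methoxy on the aromatic carbon that is ortho to two methoxy groups and para to a large group gives an at least 16-fold lower number from compound 2 to compound 3 (1.22 log units; beyond the scatter), so this single position decides whether the series gives a number in the assay at all. For the compounds shown here, compound 2 enters that step only as a limit, so the true size of the step may be greater than the printed floor: the limit of > 100000 nM in this assay, at which 1 of the 3 values shown sits. The second step, 3,5-dimethoxyphenyl in place of 2-methoxyphenyl on a saturated ring carbon, gives an 8.1-fold lower number from compound 1 to compound 3 (0.91 log units; beyond the scatter), which shows that the substitution pattern on this aryl group can move the read-out well beyond the scatter, and that two methoxy groups placed as in compound 3 outdo the single methoxy of compound 1.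

What the compounds shown leave open is whether hydrogen is the best group on that aromatic carbon, since a hydroxyl, a fluorine or an amine there could give a different result. They also do not tell whether the gain seen with compound 3 would carry over to a core other than the one shared here.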